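Benzylthio triazole phthalimides: cytotoxicity series, first ethyl homologue

The compounds below may be only part of what the source reports. "The series", "measured", "known", "first", "only" and "open" are said of these compounds alone.

Measured compounds:
Compound 1, `Cc1nnc(SCc2ccccc2)n1N1C(=O)c2ccccc2C1=O` — in a functional assay on MKN-45 cells (Homo sapiens) for cytotoxicity, read by MTT assay, with a stated time of 48 h (a lower number here means a stronger inhibitor, a higher number a weaker inhibitor), compound 1 gives > 200000 nM, a limit of the assay and not a number.
Compound 2, `CCOC(=O)CSc1nnc(C)n1N1C(=O)c2ccccc2C1=O` — compound 2 gives > 200000 nM, likewise a limit.
Compound 3, `C#CCSc1nnc(C)n1N1C(=O)c2ccccc2C1=O` — compound 3 gives > 200000 nM, again a limit.

Compound 1 therefore stands only at the limit, as do the other two, which the limit of > 200000 nM in this assay, at which 3 of the 3 values shown sit, summarises. The steps a step that the two limits leave unreadable from compound 1 to compound 2, a step that the two limits leave unreadable from compound 1 to compound 3 and a step that the two limits leave unreadable from compound 2 to compound 3 are all unreadable, and each changes the group on a saturated chain carbon bound to a sulfur. Compound 4, `CCCc1nnc(SCc2ccccc2)n1N1C(=O)c2ccccc2C1=O`, differs from compound 1 by ethyl in place of hydrogen on a saturated chain carbon bound to an aromatic carbon. For the measured compounds named here, no measured step touches this place, and none gives a readable size. With all three values at the limit, the step that the limit leaves unreadable from compound 1 to compound 4 is expected to stay unreadable. Compound 4 is estimated at 300000 nM, in a range from 100000 nM to 1000000 nM, most probably reported again as a limit.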

Compound 4, half-maximal inhibitory concentration: > 200000 nM
Compound 4 was reported as a limit (the forecaster's own chance of this, stated with the estimate: 85%); the middle value is on the limit's open side.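

No new step can be read between compound 1 and compound 4, since both stand only at a limit. The compounds shown leave open whether any change to the shared core gives a readable value in this assay.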